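This account rests on a few compounds, and the source may have more. Where it says the series, first, only, none or still open, it means among the compounds named here.

Measured so far:
compound 1, `CC1(C)S[C@@H]2/C(=C\C(=O)c3cc(C(F)(F)F)cc(C(F)(F)F)c3)C(=O)N2[C@H]1C(=O)OC(c1ccccc1)c1ccccc1`, 48500 nM;
compound 2, `CC1(C)S[C@@H]2/C(=C\C(=O)c3cc(F)cc(F)c3)C(=O)N2[C@H]1C(=O)OC(c1ccccc1)c1ccccc1`, 17600 nM.

Compound 2 has the lowest number of the two in a functional assay on OE19 cells (Homo sapiens) for cytotoxicity, read by MTT assay, with a stated time of 48 h; on this read-out higher numbers stand for weaker inhibition and lower numbers for stronger inhibition; compound 1 sits above it, and the gap lies beyond the usual scatter. Compound 3, `CC1(C)S[C@@H]2/C(=C\C(=O)c3ccc(F)cc3)C(=O)N2[C@H]1C(=O)OC(c1ccccc1)c1ccccc1`, is not yet measured. Against compound 2 it changes in one place: 4-fluorophenyl in place of 3,5-difluorophenyl on a carbonyl carbon. Going by the values given here, no step between measured compounds is available, so the expectation for compound 3 rests on the two values alone: a small shift in this assay, towards a somewhat higher number, possibly none beyond the scatter. Compound 3 is estimated at 22000 nM, range 8000 nM to 60000 nM. The expected step is a 1.3-fold higher number from compound 2 to compound 3 (0.10 log units; within the scatter).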

Compound 3, half-maximal inhibitory concentration: 12100 nM
Estimate against measurement, compound 3: 1.8-fold (0.26 log units) above; the measured number falls inside the stated range.
By their numbers in this assay, from the lowest: compounds 3 and 2 (each within the scatter of the next); then compound 1.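

In this assay, 4-fluorophenyl in place of 3,5-difluorophenyl on a carbonyl carbon gives a 1.5-fold lower number from compound 2 to compound 3 (0.16 log units; within the scatter) and so does not separate the two compounds. This single one-place comparison shows that, at this position, going from two fluorines to one leaves the read-out within its usual variation. No measured evidence bears on this result.

Still open, on these data alone, is whether plain phenyl, or a phenyl ring carrying an amine or a carboxylic acid, would shift the number beyond the scatter. As far as these compounds go, the contribution of the diphenylmethyl ester also remains open.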